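This account rests on a few compounds, and the source may have more. Where it says the series, first, only, none or still open, it means among the compounds named here.

Measured so far:
Compound 1 `O=S(=O)(Nc1ccc(-c2nc3ccccc3o2)cc1)c1cccc(O)c1` gives 62000 nM in an assay on cells for inhibition of HSP60/HSP10 (Homo sapiens), with a stated time of 60 min; on this read-out higher numbers stand for weaker inhibition and lower numbers for stronger inhibition.
Compound 2 `O=S(=O)(Nc1ccc(-c2nc3cc(NS(=O)(=O)c4cccc(O)c4)ccc3o2)cc1)c1cccc(O)c1` gives 17000 nM in this assay.
Compound 3 `O=S(=O)(Nc1ccc2oc(-c3ccccc3)nc2c1)c1ccc(Cl)c(C(F)(F)F)c1` reaches only the limit of this assay, > 100000 nM, with no number.

Of the two numbers shown, compound 1 stands highest; the only measured step, a 3.6-fold lower number from compound 1 to compound 2 (0.56 log units; beyond the scatter), adds a second sulfonamide arm on the shared core. Compound 4 `CCc1ccc(S(=O)(=O)Nc2ccc(-c3nc4ccccc4o3)cc2)cc1` differs from compound 1 by 4-ethylphenyl in place of 3-hydroxyphenyl on a sulfonyl sulfur. Among the compounds with values here, no measured step touches the group on the sulfonyl sulfur, so no step bears directly on this change; compound 3, which carries a different sulfonyl aryl on a rearranged core, is known only as a limit (the limit of > 100000 nM in this assay, at which 1 of the 3 values shown sits). Loss of the hydroxyl is expected to cost a little, estimated as a 1.5-fold higher number from compound 1 to compound 4 (0.16 log units; within the scatter). Compound 4 is therefore estimated at 90000 nM, within 30000 nM to 250000 nM.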

Compound 4, half-maximal inhibitory concentration: > 100000 nM
Compound 4: a limit, no number (the forecaster's own chance of this, stated with the estimate: 35%); middle value at least 1.1-fold (0.04 log units) away from the limit.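

The group on the sulfonyl sulfur now has its first measured step: 4-ethylphenyl in place of 3-hydroxyphenyl gives an at least 1.6-fold higher number from compound 1 to compound 4 (0.20 log units; that floor lies within the scatter). In this assay compound 4 is a limit and not a number, so the real gap could be larger than that floor. This change joins a second compound to the limit: the limit of > 100000 nM in this assay, at which 2 of the 4 values shown sit.

Going by these compounds, the swap removes the hydroxyl and adds the ethyl together, so the effect of each alone stays unknown. Also open, on these data alone, is how an amine or a carboxylic acid on that phenyl ring would read.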